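This account rests on a few compounds, and the source may have more. Where it says the series, first, only, none or still open, it means among the compounds named here.

In a physicochemical assay for acid dissociation, compound 3 `COc1ccc(F)cc1CNCCCNc1ccnc2cc(Oc3ccc(C(C)(C)C)cc3)ccc12` gives 9.28. Compound 2 `COc1cccc(Oc2ccc3c(NCCCNCc4cc(F)ccc4OC)ccnc3c2)c1` gives 9.28, and the step of no change at the digits printed from compound 2 to compound 3 (within the scatter) leaves the two level. Compound 1 `COc1ccc(F)cc1CNCCCNc1ccnc2cc(CCC(C)C)ccc12` gives 9.47, and the step of a number 0.19 log units lower from compound 1 to compound 3 (within the scatter) also stays within the scatter, so the three numbers cannot be told apart. Compound 4 `COc1ccc(F)cc1CNCCCNc1ccnc2cc(-c3ccc(F)cc3)ccc12` differs from compound 3 in one place: 4-fluorophenyl in place of 4-(tert-butyl)phenoxy on an aromatic carbon. The two measured steps at this same position, isopentyl to 4-(tert-butyl)phenoxy and 3-methoxyphenyl to 4-(tert-butyl)phenyl on the oxygen, both stayed within the scatter, so the step of a number 0.02 log units higher from compound 3 to compound 4 (within the scatter) is expected to stay within the scatter as well. For compound 4 the estimate in this assay is 9.3, with a range from 9 to 9.6.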

Compound 4, acid dissociation constant: 9.47
Compound 4: the middle estimate sits 0.17 log units below what was measured; the measured number falls inside the stated range.
By their numbers in this assay, from the lowest: compounds 2, 3, 1 and 4 (each within the scatter of the next).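

Swapping either phenoxy group for 4-fluorophenyl, which has fewer heavy atoms and no hydrogen-bond acceptor, still barely registers in this assay, giving a number 0.19 log units higher from compound 3 to compound 4 (within the scatter) and a number 0.19 log units higher from compound 2 to compound 4 (within the scatter). Replacing the isopentyl chain with the same group gives no change at the digits printed from compound 1 to compound 4 (within the scatter), so all four groups at this position remain indistinguishable in this read-out. Nothing available accounts for this lack of response. Still open, going by these compounds, is whether any group here can move the number beyond the scatter, such as an amine or a carboxylic acid in place of 4-fluorophenyl.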